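The compounds below may be only part of what the source reports. "The series", "measured", "known", "first", "only" and "open" are said of these compounds alone.

Two compounds of the series carry a measurement. Compound 1 `COc1cccc(N2CCN(C(=O)C(C)N3C(=O)CCC3=O)CC2)c1` in a functional assay on the whole organism (strain Swiss) with Mus musculus as the target, in the maximal electroshock model, with a stated time of 0.25 h, at a dose of 300 mg/kg by the intraperitoneal route (on this read-out higher numbers stand for a stronger effect at the one dose given and lower numbers for a weaker effect), gives 75%. Compound 2 `CCC(C(=O)N1CCN(c2ccccc2Cl)CC1)N1C(=O)CCC1=O` in this assay gives 50%. Compound 1 thus stands highest of the two numbers, and its nearest neighbour, compound 2, lies lower by a gap beyond the usual scatter. For the measured compounds named here, no measured pair differs in one place only, so no single structural step can be read from the numbers. Compound 3 `CC(C(=O)N1CCN(c2ccccc2F)CC1)N1C(=O)CCC1=O` has not yet been measured in this assay. Against compound 1 it shows (2-fluorophenyl in place of 3-methoxyphenyl on an amine nitrogen in a ring). Going by the values given here, the measured set offers no step for a change of this kind; the only guidance is that compound 1 stands at 75% and compound 2 at 50%. The expected step of a number 15 percentage points lower from compound 1 to compound 3 (beyond the scatter) is moderate and downward, though a result within the scatter cannot be excluded. Compound 3 is estimated at 60%, in a range from 30% to 90%.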

Compound 3, a percentage reported as activity, at one dose (the size of the read-out at that dose, not a potency): 100%
Beside the measured number, compound 3's estimate is 40 percentage points below it; the measured number lies above the stated range.
By their numbers in this assay, from the lowest: compound 2; then compound 1; then compound 3.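

In this assay, for the compounds shown here, the change from 3-methoxyphenyl to 2-fluorophenyl on an amine nitrogen in a ring gives a number 25 percentage points higher from compound 1 to compound 3 (beyond the scatter) as the first step that can be read at a single place. Going by these compounds alone, the position therefore tolerates a substituted phenyl other than the one in compound 1, and the read-out moves with the group placed there. The methoxy oxygen, the only hydrogen-bond acceptor in the leaving group, is not needed for a high read-out at this dose, and no measured property is available to account for the step.

The step changes both substituent and ring position at once, so it cannot separate the two. An unsubstituted phenyl or a 2-methoxyphenyl on the core of compound 1 would show which of them carries the step.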